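A few compounds are considered here, and "the series" means these few. Any claim that something is new, unique, unknown or untested is made for them only; others in the source may bear on it.

Compound 1 `O=S(=O)(c1ccc(F)cc1)c1cccc2oc(N3CCNCC3)nc12`: 64 nM
Compound 2 `O=S(=O)(c1cccc(Cl)c1)c1cccc2oc(N3CCNCC3)nc12`: 31 nM

For the measured compounds named here, in an assay on HeLa cells for displacement of a labelled ligand from 5-hydroxytryptamine receptor 6 (Homo sapiens) (on this read-out higher numbers stand for weaker inhibition and lower numbers for stronger inhibition), compound 2 holds the lower of the two numbers; its nearest neighbour is compound 1, and the only measured step, a 2.1-fold lower number from compound 1 to compound 2 (0.31 log units; beyond the scatter), came from exchanging the whole aryl group on the sulfonyl sulfur. Compound 3 `O=S(=O)(c1cc(Cl)ccc1Cl)c1cccc2oc(N3CCNCC3)nc12` differs from compound 2 by chloro in place of hydrogen on an aromatic carbon. Going by the values given here, no measured step adds a chloro to an aryl ring that already carries one, so the single step gives only a loose guide. The expected change from compound 2 to compound 3 is therefore a 1.0-fold lower number from compound 2 to compound 3 (0.01 log units; within the scatter), not beyond the scatter. Compound 3 is estimated at 30 nM, ranging from 12 nM to 75 nM.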

Compound 3, inhibition constant: 13 nM
The estimate for compound 3 lay 2.3-fold (0.36 log units) above the measured number; measured number inside the range.
By their numbers in this assay, from the lowest: compound 3; then compound 2; then compound 1.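

In this assay, a chloro on the aromatic carbon ortho to a large group and para to a chloro group gave a 2.4-fold lower number from compound 2 to compound 3 (0.38 log units; beyond the scatter), so the 3-chlorophenyl group on the sulfonyl sulfur accepts a second chloro here, with a change beyond the scatter. Exchanging 4-fluorophenyl for 2,5-dichlorophenyl gave a 4.9-fold lower number from compound 1 to compound 3 (0.69 log units; beyond the scatter). Nothing measured here bears on the cause of this change. On these data alone, it remains open whether a methyl or a methoxy at this carbon would do the same. The compounds also leave open whether this chloro would act alike on a ring without the first chloro.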